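Ethyl for Hydrogen on the Saturated Ring of Compound 1

The source may report more compounds than this note shows. Statements on the series, on what has been measured and on what is new or still open speak of the compounds shown alone.

Compound 1, with the structure `CO/N=C1\C[C@@H](c2ccccc2)N[C@@H](c2ccccc2)C1`, is the weakest of the three measured compounds in a functional assay on HeLa cells (Homo sapiens) for inhibition, read by MTT assay, with a stated time of 24 h (on this read-out lower numbers stand for stronger inhibition and higher numbers for weaker inhibition), where compound 1 gives 121000 nM. For the measured compounds named here, the other two measured compounds carry further changes on their aryl groups as well as a methyl on the ring, so no single step links them to compound 1; their values simply stand lower. Compound 2, with the structure `CO/N=C1\C[C@@H](c2ccc(F)cc2)N[C@@H](c2ccc(F)cc2)[C@@H]1C`, gives 49200 nM in this assay, and compound 3, with the structure `CO/N=C1\C[C@@H](c2cccc(F)c2)N[C@@H](c2cccc(F)c2)[C@@H]1C`, gives 38400 nM in this assay. Both of these numbers lie beyond the scatter from that of compound 1.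

Compound 4, with the structure `CC[C@@H]1/C(=N/OC)C[C@@H](c2ccccc2)N[C@H]1c1ccccc1`, differs from compound 1 in one place: ethyl in place of hydrogen on a saturated ring carbon, an ethyl in place of hydrogen on a saturated ring carbon of the six-membered non-aromatic ring with one nitrogen, next to the ring atom that bears a phenyl group. Going by the values given here, no measured pair shows this exact step. Because compound 2 gives 49200 nM and compound 3 gives 38400 nM, both with a small alkyl at this ring carbon, the author expects the step from compound 1 to compound 4 to be a 2.0-fold lower number from compound 1 to compound 4 (0.30 log units; within the scatter), a modest move toward stronger inhibition. On that basis compound 4 is estimated at 60000 nM, within a range from 25000 nM to 150000 nM.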

Compound 4, half-maximal inhibitory concentration: 57300 nM
Compound 4: the middle estimate sits 1.0-fold (0.02 log units) above what was measured; the measured number falls inside the stated range.
By their numbers in this assay, from the lowest: compounds 3, 2 and 4 (each within the scatter of the next); then compound 1.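

In this assay, for the compounds shown here, ethyl in place of hydrogen on a saturated ring carbon gives a 2.1-fold lower number from compound 1 to compound 4 (0.32 log units; beyond the scatter), the first single change in this set whose effect can be read on its own. The step is modest but lies beyond the scatter, so a substituent at this ring carbon is enough by itself to move the number, with the aryl groups left as plain phenyl. The earlier compounds could not show this, as each differs from compound 1 in more than one place, with its ring methyl always accompanied by fluorine on the aryl groups, and nothing at hand explains why the ethyl step has this size.

From the compounds shown here alone, what stays open is how the number depends on the group at this carbon: a methyl alone on the core of compound 1, a longer chain such as propyl, or an amine at the same place would each be a single step from compound 1. Going by these compounds, it is also open whether the ethyl step keeps its size when fluorine sits on the aryl groups, or when the ethyl takes the opposite orientation on the ring.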